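The source may hold more compounds than are shown below. What is called first, only, known or untested is meant among the compounds shown, and "the series" means these compounds.

Measured compounds:
Compound 1, `CCCCCSc1nc(NCc2ccc([Se]C)cc2)c2ccccc2n1`: > 100000 nM
Compound 2, `CSc1nc(NCc2ccc([Se]C)cc2)c2ccccc2n1`: > 100000 nM
Compound 3, `CCCCC[Se]c1nc(N)c2cccnc2n1`: 44900 nM

In an ADME assay on BEAS-2B cells (Homo sapiens) for cytotoxicity, read by MTT assay, with a stated time of 72 h (on this read-out higher numbers stand for weaker inhibition of growth and lower numbers for stronger inhibition of growth), the value of compound 1 is a limit of the assay rather than a number. The value of compound 2 in this assay is likewise a limit. Compound 3 is the only one of the three with a read number, and in this assay compound 3 gives 44900 nM.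

Compound 1 and compound 2 differ by hydrogen in place of butyl on a saturated chain carbon bound to a sulfur. The step that the two limits leave unreadable from compound 1 to compound 2 cannot be read in size, because of the limit of > 100000 nM in this assay, at which 2 of the 3 values shown sit.

Compound 4, `C[Se]c1nc(N)c2cccnc2n1`, has not yet been measured in this assay. It differs from compound 3 by hydrogen in place of butyl on a saturated chain carbon bound to a selenium atom. Within the data shown here, this is the same kind of change as the one between compound 1 and compound 2, but not the same: there the place is on a saturated chain carbon bound to a sulfur, here on a saturated chain carbon bound to a selenium atom. The difference between the core of compound 3 and the core of compound 1 is not broken down here.

Since the measured pair gives no readable step, the expectation for compound 4 rests on the read number of compound 3 and on the two limits. In this assay compound 3 gives 44900 nM. There is also (the limit of > 100000 nM in this assay, at which 2 of the 3 values shown sit), which leaves the possibility that the shorter chain again reaches only a limit. The step of a 1.8-fold higher number from compound 3 to compound 4 (0.25 log units; within the scatter) is expected to be modest. Compound 4 is estimated at 80000 nM, within 30000 nM to 250000 nM.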

Compound 4, concentration for total growth inhibition: 90800 nM
Estimate against measurement, compound 4: 1.1-fold (0.05 log units) below, and the stated range covers the measured number.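

In this assay, hydrogen in place of butyl on a saturated chain carbon bound to a selenium atom (pentyl to methyl, when cut one bond further out) gives a 2.0-fold higher number from compound 3 to compound 4 (0.31 log units; beyond the scatter) and so weaker inhibition of growth on the core of compound 3, a modest step but the only one here that can be read. On the core of compound 1, the same kind of change, there on a saturated chain carbon bound to a sulfur, cannot be read in size: the limit of > 100000 nM in this assay, at which 2 of the 4 values shown sit. The series therefore does not show that the step carries from one core to the other, since a single readable step on one core gives no size to compare, and the two pairs also differ in the atom that bears the chain.

The compounds shown leave open how the read-out would respond to a chain longer than pentyl, or to an amine or a carboxylic acid in place of the pentyl, on either core. They also leave open whether a sulfur in place of the selenium atom on the core of compound 3 would change the size of the step.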